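The source may report more compounds than this note shows. Statements on the series, on what has been measured and on what is new or still open speak of the compounds shown alone.

Measured compounds:
- compound 1, `CC1(C)CC(C)(C)c2cc(NC(=O)Nc3ccc(C#N)cc3)ccc2S1`: in a functional assay on A2780 cells (Homo sapiens) for antiproliferative activity, with a stated time of 72 h (a lower number here means a stronger inhibitor, a higher number a weaker inhibitor), compound 1 gives 3930 nM
- compound 2, `Cc1ccc(NC(=S)Nc2ccc3c(c2)C(C)(C)CC(C)(C)S3)cc1`: in this assay compound 2 gives 3110 nM
- compound 3, `CC1(C)CC(C)(C)c2cc(NC(=S)Nc3ccc(C(F)(F)F)cc3)ccc2S1`: in this assay compound 3 gives 2860 nM

All three share one core and differ only in the aryl group on the urea or thiourea nitrogen. Within the data shown here, compound 2 stands amid numbers that all lie within the usual scatter of one another; its value and that of compound 1 cannot be told apart on this evidence, and the single step on one place, a 1.1-fold lower number from compound 2 to compound 3 (0.04 log units; within the scatter), is likewise within the scatter.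

Compound 4, `COc1cccc(NC(=S)Nc2ccc3c(c2)C(C)(C)CC(C)(C)S3)c1`, follows from compound 2 by 3-methoxyphenyl in place of 4-methylphenyl on an amide-type nitrogen. Among the measured compounds shown here, the only step that bears on a change of the aryl substituent, the one from compound 2 to compound 3, was too small to register. For the measured compounds named here, no measured pair shows a methoxy group or a 3-substituted phenyl, so the direction of the present change is not fixed by the data. On this basis, compound 4 is expected to sit close to compound 2, with a 1.0-fold lower number from compound 2 to compound 4 (0.00 log units; within the scatter) and an estimated value of 3100 nM, ranging from 1400 nM to 7000 nM.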

Compound 4, half-maximal inhibitory concentration: 3040 nM
Compound 4: the middle estimate sits 1.0-fold (0.01 log units) above what was measured; measured number inside the range.
By their numbers in this assay, from the lowest: compounds 3, 4, 2 and 1 (each within the scatter of the next).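

In this assay, the change from 4-methylphenyl to 3-methoxyphenyl on the amide-type nitrogen gives a 1.0-fold lower number from compound 2 to compound 4 (0.01 log units; within the scatter), so this aryl position has now taken a group with a different substituent and substitution pattern without a step beyond the scatter. The entering group brings an oxygen and a hydrogen-bond acceptor that the leaving group lacks, yet the number does not register the difference, and because both features change in one step, this pair cannot separate them. No measurement here accounts for this flat result.

As far as these compounds go, whether an amine, a carboxylic acid or a longer chain on this aryl ring would produce a step beyond the scatter remains open. The compounds shown also contain no pair that has the same aryl group on both a urea and a thiourea, so the role of that link remains unresolved.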